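Dog liver microsome stability across a shared urea core

The source may report more compounds than this note shows. Statements on the series, on what has been measured and on what is new or still open speak of the compounds shown alone.

Measured compounds:
compound 1, `Cc1cc(C(=O)Nc2ccc(F)cn2)ccc1N(CCN1CCCC1)C(=O)Nc1ccc(Cl)cc1`, 0.558 h in an ADME assay on microsomes from liver (Canis lupus familiaris) for metabolic stability; on this read-out higher numbers stand for a longer-lived compound and lower numbers for a shorter-lived compound
compound 2, `Cc1cc(C(=O)Nc2ccc(Cl)cc2)ccc1N(CC(=O)N1CCOCC1)C(=O)Nc1ccc(Cl)cc1`, 0.617 h in this assay

Among the compounds with values here, the two numbers measured so far lie close together. Compound 1 gives 0.558 h and compound 2 gives 0.617 h; the gap between them is within the usual scatter, so no order between compound 1 and compound 2 can be read from these data. Both compounds share the same core, and compound 2 already carries the 4-chlorophenyl amide that is also present in compound 3.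

Compound 3, `Cc1cc(C(=O)Nc2ccc(Cl)cc2)ccc1N(CCN1CCCC1)C(=O)Nc1ccc(Cl)cc1`, has not yet been measured. Relative to compound 1 the change is 4-chlorophenyl in place of 5-fluoropyridin-2-yl on an amide-type nitrogen. Within the data shown here, no step between measured compounds isolates this change, so the expectation rests on the two values in hand. Because compound 2 gives 0.617 h with the 4-chlorophenyl amide in place, the step is expected to be small: for compound 3 the expected step is a 1.1-fold higher number from compound 1 to compound 3 (0.03 log units; within the scatter), not beyond the scatter in either direction. Compound 3 is therefore estimated at 0.6 h, within a range from 0.35 h to 1 h.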

Compound 3, half-life: 2.28 h
The estimate for compound 3 lay 3.8-fold (0.58 log units) below the measured number; the whole stated range lies below it.
By their numbers in this assay, from the lowest: compounds 1 and 2 (each within the scatter of the next); then compound 3.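

In this assay, the aryl group on the amide-type nitrogen matters once the (pyrrolidin-1-yl)methyl chain is in place: 4-chlorophenyl in place of 5-fluoropyridin-2-yl gives a clear step (a 4.1-fold higher number from compound 1 to compound 3 (0.61 log units; beyond the scatter)). The chain also matters with 4-chlorophenyl held constant, as (pyrrolidin-1-yl)methyl in place of (morpholin-4-yl)carbonyl on the saturated chain carbon gives a step of similar size (a 3.7-fold higher number from compound 2 to compound 3 (0.57 log units; beyond the scatter)), so the closeness of the first two numbers concealed two separate single-place steps, and only compound 3 carries both groups. Nothing on hand accounts for either step.

The aryl change swaps the ring nitrogen and the halogen together, so 4-fluorophenyl or 5-chloropyridin-2-yl on the same amide-type nitrogen would be needed to tell which of the two carries the step. The chain change likewise replaces both the morpholine ring and the carbonyl, leaving open how a (morpholin-4-yl)methyl or (pyrrolidin-1-yl)carbonyl group would read in this assay and whether the step belongs to the ring or to the carbonyl.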